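A Benzoyl Cap on the Chain of Compound 2

The source may hold more compounds than are shown below. What is called first, only, known or untested is meant among the compounds shown, and "the series" means these compounds.

Two measured compounds open this account. Compound 1 `CCCn1c(NC(=O)c2cccnn2)nc2cc(C(N)=O)cc(OC)c21` carries a propyl chain on the shared core, and compound 2 `CCn1nc(C)cc1C(=O)Nc1nc2cc(C(N)=O)cc(OC)c2n1CCCN` carries an aminopropyl chain on the same core. In an assay for activation of interferon regulatory factor 3 (Homo sapiens), read by a luciferase reporter, with a stated time of 20 h (a higher number here means that more compound is needed for the effect, a lower number that less compound is needed), compound 1 gives > 100000 nM, which is a limit of the assay and not a number. In this assay compound 2 gives > 100000 nM, again a limit of the assay rather than a number. Within the data shown here, compound 2 therefore stands at the edge of what the assay reports, and the one other value shown sits at that same edge, as the limit of > 100000 nM in this assay, at which 2 of the 2 values shown sit, records. Among the measured compounds shown here, no pair of measured compounds differs in one place, so no measured step is available.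

Compound 3 `CCn1nc(C)cc1C(=O)Nc1nc2cc(C(N)=O)cc(OC)c2n1CCCNC(=O)c1ccccc1` is the compound still to be measured. It differs from compound 2 by benzoyl in place of hydrogen on an amine nitrogen. With both measured values resting at a limit, the expected step of a number no higher from compound 2 to compound 3 (the limit leaves the size open) is none beyond the usual scatter. Compound 3 is thus expected to give about 100000 nM in this assay, within a range from 20000 nM to 500000 nM.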

Compound 3, half-maximal effective concentration: > 100000 nM
Compound 3: no number, only a limit (the forecaster's own chance of this, stated with the estimate: 75%); the middle value sits exactly at the limit.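

In this assay compound 3 gives > 100000 nM, which is a limit of the assay and not a number. Among these compounds, compound 2 rests at a limit as well, so no step from compound 2 to compound 3 can be read. The compounds shown leave open what number any of them would give, and all share one edge: the limit of > 100000 nM in this assay, at which 3 of the 3 values shown sit.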